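The compounds below may be only part of what the source reports. "The series", "measured", "known", "first", "only" and "open" are said of these compounds alone.

Measured so far in an ADME assay on HeLa cells (Homo sapiens) for cytotoxicity, read by MTT assay; on this read-out lower numbers stand for stronger inhibition and higher numbers for weaker inhibition:
compound 1, `N#Cc1c(-c2ccc([N+](=O)[O-])cc2)c(C#N)c(=O)n(/N=C/c2cn(-c3ccccc3)nc2-c2ccccc2)c1N`, a limit of > 200 ug/mL
compound 2, `N#Cc1c(-c2ccc(Br)cc2)c(C#N)c(=O)n(/N=C/c2cn(-c3ccccc3)nc2-c2ccccc2)c1N`, a limit of > 200 ug/mL

Compound 2 stands at the limit of this assay, not at a number. The same holds for compound 1 (the limit of > 200 ug/mL in this assay, at which 2 of the 2 values shown sit), so the series gives no readable number at all so far. For the measured compounds named here, the one step between measured compounds, bromo in place of nitro on an aromatic carbon, is a step that the two limits leave unreadable from compound 1 to compound 2; its size cannot be read, since both ends are limits.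

Compound 3, `N#Cc1c(-c2ccccc2C(F)(F)F)c(C#N)c(=O)n(/N=C/c2cn(-c3ccccc3)nc2-c2ccccc2)c1N`, carries the change (2-(trifluoromethyl)phenyl in place of 4-bromophenyl on an aromatic carbon), in words 2-(trifluoromethyl)phenyl in place of 4-bromophenyl on an aromatic carbon. Going by the values given here, the only measured step bears on the same position and is unreadable, so it offers no size and no direction for this change in this assay. With two of two values sitting at the limit (the limit of > 200 ug/mL in this assay, at which 2 of the 2 values shown sit), the expectation for compound 3 is again a value at or past that limit, with no step beyond the scatter. The step expected from compound 2 to compound 3 is therefore estimated as a step that the limit leaves unreadable from compound 2 to compound 3. Compound 3 is estimated at 250 ug/mL, within 120 ug/mL to 500 ug/mL.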

Compound 3, half-maximal inhibitory concentration: > 200 ug/mL
Compound 3 was reported as a limit; the forecaster's own chance of this, stated with the estimate: 85%; the middle value lies beyond the limit too.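

In this assay compound 3 gives > 200 ug/mL, which is a limit and not a number. No step among compound 1, compound 2 and compound 3 can be read, since every value is a limit: the limit of > 200 ug/mL in this assay, at which 3 of the 3 values shown sit.

The compounds shown leave open whether any group at this position gives a readable value in this assay.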